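The compounds below may be only part of what the source reports. "The series", "measured", "known", "first", "only" and "open" are said of these compounds alone.

Of the compounds shown here, three that share one core have been measured in a functional assay on IMR-32 cells (Homo sapiens) for antiproliferative activity, read by sulforhodamine B assay, with a stated time of 48 h; a higher number here means a weaker inhibitor of growth, a lower number a stronger inhibitor of growth. Compound 1 `O=C1COc2ccccc2N1CCCn1cc(-c2ccccc2)nn1` gives 370 nM, and compound 3 `COc1ccc2cc(-c3cn(CCCN4C(=O)COc5ccccc54)nn3)ccc2c1` gives 1300 nM. Compound 2 `Cc1ccc(-c2cn(CCCN3C(=O)COc4ccccc43)nn2)cc1` gives 4400 nM, the highest number of the three and so the weakest inhibition of growth in this small set.

The next structure is compound 4 `COc1ccc(-c2cn(CCCN3C(=O)COc4ccccc43)nn2)cc1`, which departs from compound 2 by a single change, methoxy in place of methyl on an aromatic carbon, or 4-methylphenyl to 4-methoxyphenyl. Going by the values given here, no measured step makes this exact exchange. The closest evidence is a 12-fold higher number from compound 1 to compound 2 (1.08 log units; beyond the scatter), a large step that comes from methyl in place of hydrogen on that same aromatic carbon. It shows that the number can move far with a small change at this carbon. Compound 3, which also carries a methoxy group but differs in its aromatic part, stands at 1300 nM, which gives indirect support for a number lower than that of compound 2.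

A moderate step towards stronger inhibition therefore seems likely, smaller than the one measured and with real uncertainty. The estimate means a 2.9-fold lower number from compound 2 to compound 4 (0.47 log units; beyond the scatter), as an expected step. For compound 4 the expected value is 1500 nM, with an estimated range of 400 nM to 5000 nM.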

Compound 4, concentration for 50% growth inhibition: 49900 nM
The estimate for compound 4 lay 33-fold (1.52 log units) below the measured number; measured number outside the range, above it.
By their numbers in this assay, from the lowest: compound 1; then compound 3; then compound 2; then compound 4.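

In this assay, putting methoxy in place of methyl on this aromatic carbon gives an 11-fold higher number from compound 2 to compound 4 (1.05 log units; beyond the scatter), so the number does not fall back towards that of the unsubstituted compound but climbs further in the direction methyl had already taken. Set against hydrogen, methoxy gives a 130-fold higher number from compound 1 to compound 4 (2.13 log units; beyond the scatter), a far larger move than a 12-fold higher number from compound 1 to compound 2 (1.08 log units; beyond the scatter), so both groups tried at this carbon go with weaker inhibition of growth, and the hydrogen of compound 1 gives the lowest number of the series. Nothing available accounts for this steep rise at this carbon, or for how far it goes with methoxy.

With only hydrogen, methyl and methoxy at this carbon, the compounds leave open whether another group, such as a chlorine atom, a hydroxyl or an amine, would stay near compound 1 or climb as far as compound 4. They also leave open whether the same steep rise would appear if the chain joining the two halves of the molecule were replaced by a longer chain.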